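Azetidinylsulfonylethyl in place of methanesulfonamido on the core nitrogen

The source may report more compounds than this note shows. Statements on the series, on what has been measured and on what is new or still open speak of the compounds shown alone.

Compound 1 `CS(=O)(=O)NNc1nonc1/C(=N/O)Nc1ccc(F)c(Br)c1` carries a methanesulfonamido on a nitrogen on an aromatic ring. In an assay on HeLa cells for inhibition of Indoleamine 2,3-dioxygenase 1 (Homo sapiens), read by spectrophotometry, with a stated time of 24 h (a higher number here means that more compound is needed for the effect, a lower number that less compound is needed), compound 1 gives only a limit, > 800 nM, sitting at the limit of > 800 nM in this assay, at which 1 of the 2 values shown sits. Compound 2 `N=S1(=O)CC(Nc2nonc2/C(=N/O)Nc2ccc(F)c(Br)c2)C1` gives 53 nM in this assay, and the step of an at least 15-fold lower number from compound 1 to compound 2 (1.17 log units; beyond the scatter) shows that exchanging the methanesulfonamido for a group holding a four-membered ring lowers the number sharply. Compound 3 `O=S(=O)(CCNc1nonc1/C(=N/O)Nc1ccc(F)c(Br)c1)N1CCC1` makes the change (2-((azetidin-1-yl)sulfonyl)ethyl in place of methanesulfonamido on a nitrogen on an aromatic ring). Among the measured compounds shown here, only the step from compound 1 to compound 2 bears on it, so a drop of similar size is expected, an at least 10-fold lower number from compound 1 to compound 3 (1.00 log units; beyond the scatter). Compound 3 is estimated at 80 nM, between 20 nM and 400 nM.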

Compound 3, half-maximal effective concentration: 143 nM
Compound 3: middle estimate off by 1.8-fold (0.25 log units), on the low side; the measured number falls inside the stated range.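

Replacing methanesulfonamido with 2-((azetidin-1-yl)sulfonyl)ethyl on a nitrogen on an aromatic ring gives, in this assay, an at least 5.5-fold lower number from compound 1 to compound 3 (0.74 log units; beyond the scatter), so the drop in the number is not tied to the group of compound 2 alone. The two groups holding a four-membered ring are still not equivalent, with a 2.7-fold higher number from compound 2 to compound 3 (0.43 log units; beyond the scatter). The step from compound 1 remains open-ended, since compound 1 gives only a limit: the limit of > 800 nM in this assay, at which 1 of the 3 values shown sits.

Open, going by these compounds, is whether the azetidine ring matters at all. A dimethylamine in its place on the sulfonyl, or a carboxylic acid at the end of the ethyl chain, would bear on this.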